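The source may hold more compounds than are shown below. What is called first, only, known or untested is meant among the compounds shown, and "the series" means these compounds.

In a functional assay on the whole organism (Tail, strain ICR) with Mus musculus as the target, in the tail flick test, with a stated time of 30 min, at a dose of 25 umol/kg by the oral route (on this read-out lower numbers stand for a weaker effect and higher numbers for a stronger effect at the one dose given), compound 3 `CC(C)[C@H](NC(=O)CN(c1nc(Cl)nc2[nH]cnc12)C1CC1)C(=O)OCc1ccccc1` gives 33.4%, the second highest of the three numbers. Compound 1 `O=C(CN(c1nc(Cl)nc2[nH]cnc12)C1CC1)N[C@@H](CO)C(=O)OCc1ccccc1` gives 31.9%, within the scatter of compound 3, while compound 2 `N=C(N)NCCC[C@H](NC(=O)CN(c1nc(Cl)nc2[nH]cnc12)C1CC1)C(=O)O` gives 45.4%, a number beyond the scatter above it. Among the measured compounds shown here, the one measured single-place step, a number 1.5 percentage points higher from compound 1 to compound 3 (within the scatter), lay within the scatter. Compound 4 `N=C(N)NCCC[C@H](NC(=O)CN(c1nc(Cl)nc2[nH]cnc12)C1CC1)C(=O)OCc1ccccc1` differs from compound 3 in one place: a group of 7 heavy atoms (4 carbon, 3 nitrogen; no ring) in place of a group of 3 heavy atoms (3 carbon; no ring), on a saturated chain carbon bound to an amide-type nitrogen and a carbonyl carbon. For the measured compounds named here, no measured step carries this exact change; the step from compound 1 to compound 3 did not involve the entering group, and compound 2, which carries it in an otherwise different molecule, only hints at a higher number. Compound 4 is therefore expected at 40%, between 25% and 55%. The expected step is a number 6.6 percentage points higher from compound 3 to compound 4 (within the scatter), with wide uncertainty.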

Compound 4, a percentage reported as activity, at one dose (the size of the read-out at that dose, not a potency): 23.2%
The estimate for compound 4 lay 16.8 percentage points above the measured number; measured number below the stated range.
By their numbers in this assay, from the lowest: compounds 4, 1 and 3 (each within the scatter of the next, the first and the last beyond it); then compound 2.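

In this assay there is a number 10.2 percentage points lower from compound 3 to compound 4 (beyond the scatter) when the larger group replaces isopropyl, so at this chain carbon the group does not raise the number. There is also a number 22.2 percentage points lower from compound 2 to compound 4 (beyond the scatter) when benzyl replaces hydrogen on an oxygen next to a carbonyl group, so the high number of compound 2 does not come from the entering group alone. Set against the hydroxymethyl compound, the group gives a number 8.7 percentage points lower from compound 1 to compound 4 (within the scatter) and no separation.

From the compounds shown here alone, whether an amine on a shorter chain would behave the same on either the benzyl or the hydrogen form stays open. Nothing at hand explains why these numbers move.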